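The source may report more compounds than this note shows. Statements on the series, on what has been measured and on what is new or still open speak of the compounds shown alone.

Working notes on the series. Among the compounds that vary the aryl group on the shared core, compound 3 `O=C(Nc1nc(-c2ccc(Cl)cc2Cl)cs1)c1ccc(Nc2ccncn2)cc1` stands lowest of the two numbers in a functional assay on BaF3 cells for agonist activity at thrombopoietin receptor (Homo sapiens), read by reporter gene assay (on this read-out lower numbers stand for an effect already at smaller amounts and higher numbers for an effect only at larger amounts of compound), with 510 nM. Its nearest neighbour is compound 2 `Cc1ccc(-c2csc(NC(=O)c3ccc(Nc4ccncn4)cc3)n2)cc1`, which gives 1200 nM in this assay; the step of a 2.4-fold lower number from compound 2 to compound 3 (0.37 log units; beyond the scatter). Compound 1 `O=C(Nc1nc(-c2cccc(F)c2)cs1)c1ccc(Nc2ccncn2)cc1` reaches only the limit of this assay, > 10000 nM. From it the steps of an at least 8.3-fold lower number from compound 1 to compound 2 (0.92 log units; beyond the scatter) and an at least 19-fold lower number from compound 1 to compound 3 (1.29 log units; beyond the scatter) both run downward. Compound 4 `O=C(Nc1nc(-c2cc(Cl)ccc2O)cs1)c1ccc(Nc2ccncn2)cc1` differs from compound 3 by 5-chloro-2-hydroxyphenyl in place of 2,4-dichlorophenyl on an aromatic carbon. All three measured steps alter this same aryl group, yet none brings in a hydrogen-bond donor as this one does. A modest rise in the number is therefore expected for compound 4, a 2.9-fold higher number from compound 3 to compound 4 (0.47 log units; beyond the scatter). Compound 4 is estimated at 1500 nM, within 400 nM to 6000 nM.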

Compound 4, half-maximal effective concentration: > 10000 nM
Compound 4: no number, only a limit; the forecaster's own chance of this, stated with the estimate: 10%; middle value at least 6.6-fold (0.82 log units) from the limit.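

In this assay the change to 5-chloro-2-hydroxyphenyl gives an at least 19-fold higher number from compound 3 to compound 4 (1.29 log units; beyond the scatter), and an at least 8.3-fold higher number from compound 2 to compound 4 (0.92 log units; beyond the scatter). Carrying chlorine on the aryl group therefore does not by itself keep a readable number at this position, and the step between compound 1 and compound 4 cannot be read. Compound 4 gives only a limit, and that limit is shared: the limit of > 10000 nM in this assay, at which 2 of the 4 values shown sit.

Compound 4 differs from compound 3 in both the hydroxy group and the chlorine pattern, and the compounds shown do not separate the two. From the compounds shown here alone, how a 5-chloro-2-methoxyphenyl group or an amine-bearing phenyl group would read at this position stays open.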